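A few compounds are considered here, and "the series" means these few. Any claim that something is new, unique, unknown or untested is made for them only; others in the source may bear on it.

Compound 1 `COc1ccc(/C=C/C2(C)C=CC(=O)O2)cc1OC` gives 193000 nM
Compound 2 `CC1(/C=C/c2cccc(O)c2)C=CC(=O)O1` gives 118000 nM

Among the compounds with values here, in a functional assay on U-251 cells (Homo sapiens) for inhibition, read by sulforhodamine B assay, with a stated time of 48 h (on this read-out higher numbers stand for weaker inhibition of growth and lower numbers for stronger inhibition of growth), compound 2 and compound 1 lie within the usual scatter of each other, so compound 2 stands level with the only other measured compound. Compound 3 `COc1cccc(/C=C/C2(C)C=CC(=O)O2)c1` differs from compound 2 by methyl in place of hydrogen on an oxygen on an aromatic ring, hydroxy to methoxy (methyl in place of hydrogen on an oxygen on an aromatic ring). Within the data shown here, no two measured compounds differ in one place only, so the data give no direct size for this change. Compound 1 (193000 nM) bears methoxy and compound 2 (118000 nM) bears hydroxy, yet their values stay within the scatter. The step of a 1.3-fold higher number from compound 2 to compound 3 (0.10 log units; within the scatter) is therefore expected to stay within the scatter too, with neither direction favoured. Compound 3 is estimated at 150000 nM in a range from 70000 nM to 300000 nM as the expected outcome.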

Compound 3, concentration for total growth inhibition: 37600 nM
Compound 3: middle estimate off by 4.0-fold (0.60 log units), on the high side; the measured number lies below the stated range.
By their numbers in this assay, from the lowest: compound 3; then compounds 2 and 1 (each within the scatter of the next).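

In this assay methyl in place of hydrogen on an oxygen on an aromatic ring gives a 3.1-fold lower number from compound 2 to compound 3 (0.50 log units; beyond the scatter) and so puts a first measured size on this change, one that lies beyond the scatter. Hydrogen in place of methoxy on an aromatic carbon gives a 5.1-fold lower number from compound 1 to compound 3 (0.71 log units; beyond the scatter) and also lies beyond the scatter, so compound 3 stands apart from compound 1 and compound 2, which remain within the scatter of each other. Nothing available gives a reason for either step.

The compounds shown leave open whether the lower number belongs to methoxy specifically or would also appear with a longer chain on that oxygen, such as ethoxy. They also leave open what an amine or a fluorine atom would do in place of methoxy at this place.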